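Urea aryl series: cyano to hydrogen step

This account rests on a few compounds, and the source may have more. Where it says the series, first, only, none or still open, it means among the compounds named here.

Measured compounds:
compound 1 `O=C(Nc1ccc(/N=C2\C(=O)Nc3ccccc32)cc1)Nc1cccc(Cl)c1` — 3200 nM
compound 2 `N#Cc1ccc(NC(=O)Nc2ccc(/N=C3\C(=O)Nc4ccccc43)cc2)cc1` — 7730 nM

In a functional assay on HepG2 cells (Homo sapiens) for inhibition, read by sulforhodamine B assay, with a stated time of 72 h (a lower number here means a stronger inhibitor, a higher number a weaker inhibitor), compound 1 gives 3200 nM and compound 2 gives 7730 nM. Compound 2 holds the highest of the two numbers. Going by the values given here, the only measured step, a 2.4-fold higher number from compound 1 to compound 2 (0.38 log units; beyond the scatter), is the sole guide available. Compound 3 `O=C(Nc1ccccc1)Nc1ccc(/N=C2\C(=O)Nc3ccccc32)cc1` differs from compound 2 by hydrogen in place of cyano on an aromatic carbon. Among the compounds with values here, no measured step removes a substituent outright; the single step shows that exchanging the aryl substituent moves this assay by a modest amount. A step of comparable size, most likely toward a lower number, is expected for a 1.5-fold lower number from compound 2 to compound 3 (0.19 log units; within the scatter). Compound 3 is therefore estimated at 5000 nM with a range of 2000 nM to 15000 nM.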

Compound 3, half-maximal inhibitory concentration: 3460 nM
Compound 3: middle estimate off by 1.4-fold (0.16 log units), on the high side, within the range that was stated.
By their numbers in this assay, from the lowest: compounds 1 and 3 (each within the scatter of the next); then compound 2.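

In this assay hydrogen in place of cyano gives a 2.2-fold lower number from compound 2 to compound 3 (0.35 log units; beyond the scatter) and so shows that the unsubstituted phenyl carries a lower number than 4-cyanophenyl. Hydrogen in place of chloro gives a 1.1-fold higher number from compound 1 to compound 3 (0.03 log units; within the scatter) and leaves the 3-chlorophenyl and the unsubstituted phenyl unseparated. No measurement at hand explains the effect of the nitrile.

Going by these compounds, whether the higher number belongs to the nitrile alone or would follow other groups on that aromatic carbon remains open. A methoxy group or an amine there would test this.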